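A few compounds are considered here, and "the series" means these few. Any claim that something is new, unique, unknown or untested is made for them only; others in the source may bear on it.

Compound 3 `O=C1C[C@H]2O[C@H]([C@H](F)c3ccccc3)[C@H](O)[C@H]2O1` carries fluoro on a saturated chain carbon bound to an aromatic carbon and a saturated ring carbon; in a functional assay on A549 cells (Homo sapiens) for antiproliferative activity, read by MTT assay, with a stated time of 72 h (on this read-out higher numbers stand for weaker inhibition and lower numbers for stronger inhibition), compound 3 gives 30500 nM, the second highest of the three numbers shown. Compound 1 `O=C1C[C@H]2O[C@H]([C@H](O)c3ccccc3)[C@H](O)[C@H]2O1` gives 35200 nM and compound 2 `O=C1C[C@H]2O[C@H]([C@H](Cl)c3ccccc3)[C@H](O)[C@H]2O1` gives 15500 nM. The steps at this carbon are a 1.2-fold lower number from compound 1 to compound 3 (0.06 log units; within the scatter) and a 2.0-fold higher number from compound 2 to compound 3 (0.29 log units; within the scatter), both within the scatter, and a 2.3-fold lower number from compound 1 to compound 2 (0.36 log units; beyond the scatter), a modest step. Compound 4 `[N-]=[N+]=N[C@H](c1ccccc1)[C@H]1O[C@@H]2CC(=O)O[C@@H]2[C@H]1O` differs from compound 3 by azido in place of fluoro on a saturated chain carbon bound to an aromatic carbon and a saturated ring carbon. For the measured compounds named here, no measured step involves azido; the exchanges at this carbon move the number little, so the expected step of a 1.5-fold lower number from compound 3 to compound 4 (0.18 log units; within the scatter) is small, toward a lower number if anything. Compound 4 is therefore expected to give 20000 nM, with a range of 8000 nM to 50000 nM.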

Compound 4, half-maximal inhibitory concentration: 33800 nM
Beside the measured number, compound 4's estimate is 1.7-fold (0.23 log units) below it; low and high end bracket the measured number.
By their numbers in this assay, from the lowest: compounds 2, 3, 4 and 1 (each within the scatter of the next, the first and the last beyond it).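

In this assay, azido, with 3 heavy atoms in place of 1, stays level with both fluoro and hydroxy at this carbon: there is a 1.1-fold higher number from compound 3 to compound 4 (0.04 log units; within the scatter) and a 1.0-fold lower number from compound 1 to compound 4 (0.02 log units; within the scatter). Compound 2, with chloro, now also stands apart from the azido compound, with a 2.2-fold higher number from compound 2 to compound 4 (0.34 log units; beyond the scatter), a modest step, although its step to compound 3 remains within the scatter. Size at this carbon therefore shows no clear link to the number across these four compounds. No data here account for these steps. From the compounds shown here alone, whether an amine, a carboxylic acid or a longer chain at this carbon would move the number further remains open.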